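A Larger Bicyclic Group Replaces the Aminopyridine

This account rests on a few compounds, and the source may have more. Where it says the series, first, only, none or still open, it means among the compounds named here.

Of the compounds shown here, three have been tested in a functional assay on K562/Adr cells (Homo sapiens) for inhibition, read by MTT assay, with a stated time of 48 h, tested at 30 uM; on this read-out higher numbers stand for more inhibition at the one concentration tested (going by the name of the read-out) and lower numbers for less inhibition. Compound 1 `CC(C)(C)OC(=O)N1C[C@@H](n2cc(-c3ccc(N)nc3)nn2)C[C@H]1C(=O)Nc1ccc(Cl)c(C(F)(F)F)c1` gives 48.6%. Compound 2 `O=C(Nc1n[nH]c2cc(-c3cn([C@@H]4CN[C@H](C(=O)Nc5ccc(Cl)cc5Cl)C4)nn3)ccc12)C1CC1` gives 43.3%, and compound 3 `O=C(Nc1n[nH]c2cc(-c3cn([C@@H]4CN[C@H](C(=O)Nc5ccc(Br)cc5)C4)nn3)ccc12)C1CC1` gives 39.6%. Compound 1 has the highest of the three numbers, but its gaps to compound 2 and to compound 3 both lie within the usual scatter of such measurements, so the three compounds cannot really be told apart on these data. Among the compounds with values here, the only measured step, a number 3.7 percentage points lower from compound 2 to compound 3 (within the scatter), concerns the aryl group on the amide nitrogen and also stays within the scatter.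

The unmeasured compound 4 `CC(C)(C)OC(=O)N1C[C@@H](n2cc(-c3ccc4nc(N)sc4n3)nn2)C[C@H]1C(=O)Nc1ccc(Cl)c(C(F)(F)F)c1` differs from compound 1 at another place: a group of 10 heavy atoms (6 carbon, 3 nitrogen, 1 sulfur; one five-membered aromatic ring with 2 hetero atoms, one six-membered aromatic ring with 1 hetero atom) in place of a group of 7 heavy atoms (5 carbon, 2 nitrogen; one six-membered aromatic ring with 1 hetero atom), on an aromatic carbon. Within the data shown here, no measured step touches that position, so nothing here shows how the read-out answers to a change of this kind. Among the measured compounds shown here, the one measured step, a number 3.7 percentage points lower from compound 2 to compound 3 (within the scatter), lies elsewhere in the molecule and within the scatter, and it gives no reason to expect a shift beyond the scatter in this assay either. Compound 4 is therefore expected to give about 48%, with a range from 30% to 65%. This corresponds to an expected step of a number 0.6 percentage points lower from compound 1 to compound 4 (within the scatter), which stays within the scatter.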

Compound 4, a percentage reported as inhibition, at one concentration (the size of the read-out at that concentration, not a potency): 27.4%
Beside the measured number, compound 4's estimate is 20.6 percentage points above it; the measured number lies below the stated range.
By their numbers in this assay, from the lowest: compound 4; then compounds 3, 2 and 1 (each within the scatter of the next).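

At the aromatic carbon of the five-membered aromatic ring with 3 nitrogen, this assay does respond to the group carried there: putting the larger two-ring group in place of 6-aminopyridin-3-yl gives a number 21.2 percentage points lower from compound 1 to compound 4 (beyond the scatter). Within the data shown here, this is the first step to lie beyond the scatter, unlike the earlier change on the amide nitrogen, so this position matters more to the read-out than the three earlier compounds could show. The entering group has the same count of hydrogen-bond donors and the same lack of net charge as the group it replaces, and no supporting measurement here accounts for the lower number.

The change adds a second ring, a sulfur atom and more hydrogen-bond acceptors all at once, so the compounds shown cannot say which of these goes with the drop. From the compounds shown here alone, it also stays open whether a plain phenyl, a 2-aminopyrimidin-5-yl or a 6-methylaminopyridin-3-yl group at this carbon would hold the read-out near that of compound 1 or take it lower, as the two-ring group does.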